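Bromo for Trifluoromethyl: Expected Tolerance of Compound 4

The source may report more compounds than this note shows. Statements on the series, on what has been measured and on what is new or still open speak of the compounds shown alone.

compound 1 `COc1cccc(N2C(=O)/C(=C/c3cc(C)n(-c4cccc(-c5nnn[nH]5)c4)c3C)SC2=S)c1`: 40600 nM
compound 2 `Cc1cc(/C=C2\SC(=S)N(c3cccc([N+](=O)[O-])c3)C2=O)c(C)n1-c1cccc(-c2nnn[nH]2)c1`: 77000 nM
compound 3 `Cc1cc(/C=C2\SC(=S)N(c3ccc(C(F)(F)F)cc3)C2=O)c(C)n1-c1cccc(-c2nnn[nH]2)c1`: 27100 nM

All three were tested in an ADME assay on MT2 cells (Homo sapiens) for cytotoxicity, read by XTT assay, with a stated time of 4 days; a lower number here means that less compound is tolerated, a higher number that more compound is tolerated. Compound 3 sits at the low end of these numbers, but the step of a 1.5-fold lower number from compound 1 to compound 3 (0.18 log units; within the scatter) is within the scatter, and only a 2.8-fold lower number from compound 2 to compound 3 (0.45 log units; beyond the scatter) sets it clearly apart. Compound 4 `Cc1cc(/C=C2\SC(=S)N(c3ccc(Br)cc3)C2=O)c(C)n1-c1cccc(-c2nnn[nH]2)c1` differs from compound 3 by bromo in place of trifluoromethyl on an aromatic carbon. For the measured compounds named here, no measured step swaps one group for another on this phenyl ring; the steps that touch this ring, a 1.5-fold lower number from compound 1 to compound 3 (0.18 log units; within the scatter) and a 2.8-fold lower number from compound 2 to compound 3 (0.45 log units; beyond the scatter), exchange the whole ring and stay within or only modestly beyond the scatter. A step within the scatter is therefore expected, namely a 1.1-fold higher number from compound 3 to compound 4 (0.04 log units; within the scatter). Compound 4 is expected to give about 30000 nM, between 15000 nM and 60000 nM.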

Compound 4, half-maximal cytotoxic concentration: 46800 nM
For compound 4 the middle estimate is 1.6-fold (0.19 log units) below the measured one; the measured number falls inside the stated range.
By their numbers in this assay, from the lowest: compounds 3, 1, 4 and 2 (each within the scatter of the next, the first and the last beyond it).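

In this assay, for the compounds shown here, the first direct exchange of one group for another at this place, para to a large group, gives a small step (a 1.7-fold higher number from compound 3 to compound 4 (0.24 log units; within the scatter)), so bromo and trifluoromethyl cannot be told apart here. Compound 4 also stays close to the compounds with a different ring on the amide-type nitrogen (a 1.6-fold lower number from compound 2 to compound 4 (0.22 log units; within the scatter); a 1.2-fold higher number from compound 1 to compound 4 (0.06 log units; within the scatter)). No measurement shown here offers an explanation for these small steps.

Going by these compounds, whether an amine, a carboxylic acid or a longer chain at this ring carbon would move the number beyond the scatter remains open.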